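The source may hold more compounds than are shown below. What is called first, only, known or untested is meant among the compounds shown, and "the series" means these compounds.

Compound 1 `NC1CCC(Nc2nc(NCc3ccc(Br)cc3)c3ncn(C4CCCC4)c3n2)CC1`: 995 nM
Compound 2 `NC1CCC(Nc2nc(NCc3ccc(-c4cccs4)nc3)c3ncn(C4CCCC4)c3n2)CC1`: 32 nM

These two compounds were tested in a functional assay on HOS cells (Homo sapiens) for inhibition, with a stated time of 72 h; on this read-out lower numbers stand for stronger inhibition and higher numbers for weaker inhibition. Compound 2, at 32 nM, holds the lower of the two numbers, and so the stronger inhibition, while compound 1 gives 995 nM. The gap between them is a 31-fold lower number from compound 1 to compound 2 (1.49 log units; beyond the scatter), a large change that comes with replacing 4-bromophenyl by 6-(thiophen-2-yl)pyridin-3-yl.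

Compound 3 `NC1CCC(Nc2nc(NCc3ccc(-c4ccsc4)nc3)c3ncn(C4CCCC4)c3n2)CC1` keeps every atom of compound 2 and joins them differently, with thiophen-3-yl in place of thiophen-2-yl on an aromatic carbon. Going by the values given here, the only measured step swapped a whole group, so it says little about this much smaller edit. Among the compounds with values here, no measured pair shows what moving the attachment point on the thiophene does. From the compounds shown here alone, with so little to go on, a shift beyond the usual scatter is not expected, and either direction remains open, with a slight lean towards a higher number. The expected change is a 1.3-fold higher number from compound 2 to compound 3 (0.10 log units; within the scatter). For compound 3 the estimated value is 40 nM, with an expected range of 15 nM to 100 nM.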

Compound 3, half-maximal inhibitory concentration: 89 nM
Estimate against measurement, compound 3: 2.2-fold (0.35 log units) below; low and high end bracket the measured number.
By their numbers in this assay, from the lowest: compound 2; then compound 3; then compound 1.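

In this assay, the point at which the thiophene is attached matters: thiophen-3-yl in place of thiophen-2-yl, on an aromatic carbon next to the ring nitrogen, gives a 2.8-fold higher number from compound 2 to compound 3 (0.44 log units; beyond the scatter), a modest step but one beyond the scatter, even though the atoms and the counts of donors and acceptors stay the same. Most of the earlier gain survives this move, since 6-(thiophen-3-yl)pyridin-3-yl in place of 4-bromophenyl still gives an 11-fold lower number from compound 1 to compound 3 (1.05 log units; beyond the scatter), so among these three compounds the large drop from the 4-bromophenyl compound holds for both thiophene attachments, with thiophen-2-yl ahead. Nothing measured here explains why the two attachments differ.

The step away from 4-bromophenyl changes the outer ring and the inner ring at once, so the shares of the six-membered aromatic ring with 1 nitrogen and of the thiophene cannot be told apart. From the compounds shown here alone, whether furan-2-yl or a plain phenyl at the same carbon would follow thiophen-2-yl, thiophen-3-yl or neither also stays open, and so does the part played by the sulfur atom.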